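A few compounds are considered here, and "the series" means these few. Any claim that something is new, unique, unknown or untested is made for them only; others in the source may bear on it.

Measured so far:
- compound 1, `OC1CCCc2nc(-c3ccc(N4CCCC4)cc3)sc21`: 2800 nM
- compound 2, `CN(C)c1ccc(-c2nc3c(s2)C(O)CCC3)c(CO)c1`: 60 nM
- compound 3, `Cc1cc(N(C)C)ccc1-c1nc2c(s1)[C@@H](O)CCC2`: 1160 nM

In a functional assay on cells (Homo sapiens) for cytotoxicity, read by sulforhodamine B assay, with a stated time of 2 days (a lower number here means a stronger inhibitor, a higher number a weaker inhibitor), compound 2 gives 60 nM, the lowest of the three numbers. The nearest is compound 3 with 1160 nM; the furthest is compound 1 with 2800 nM. Both gaps lie well beyond the usual scatter, so compound 2 stands apart from the other two. Among the measured compounds shown here, compound 1 and compound 3 differ from compound 2 in more than one place each, so no single step between measured compounds is available.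

Compound 4, `OCc1cc(N2CCCC2)ccc1-c1nc2c(s1)C(O)CCC2`, is not yet measured. It differs from compound 2 as follows: pyrrolidin-1-yl in place of dimethylamino on an aromatic carbon. The hydroxymethyl group of compound 2 is kept. The same pyrrolidin-1-yl group is present in compound 1, but compound 1 lacks the hydroxymethyl group, so its value says little on its own about this change.

Because compound 2 gives 60 nM and the change adds two carbon atoms without altering the donor or acceptor count, a modest step in this assay is expected, most likely toward a higher number, but not confidently beyond the scatter. The expected step is a 2.5-fold higher number from compound 2 to compound 4 (0.40 log units; beyond the scatter). For compound 4 the estimate is 150 nM, with a range from 40 nM to 600 nM.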

Compound 4, half-maximal inhibitory concentration: 44 nM
The estimate for compound 4 lay 3.4-fold (0.53 log units) above the measured number; the range from low to high includes it.
By their numbers in this assay, from the lowest: compounds 4 and 2 (each within the scatter of the next); then compound 3; then compound 1.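

Notes on the series: in this assay, a 1.4-fold lower number from compound 2 to compound 4 (0.13 log units; within the scatter), so at this aromatic carbon, para to a large group, pyrrolidin-1-yl and dimethylamino cannot be told apart while the hydroxymethyl group is kept. Among the compounds shown here, with pyrrolidin-1-yl held in place, hydroxymethyl in place of hydrogen on an aromatic carbon gives a 64-fold lower number from compound 1 to compound 4 (1.80 log units; beyond the scatter), the first one-place reading of the hydroxymethyl group and a large step beyond the scatter. Nothing at hand bears on the reason for the size of either step.

Still open, on these data alone, is how far the tolerance at the amine position extends, for example to piperidin-1-yl, morpholin-4-yl or a primary amine, and whether it would also hold without the hydroxymethyl group. Also open, as far as these compounds go, is whether the large step belongs to the hydroxymethyl group specifically or would also appear with methoxymethyl, aminomethyl or a carboxylic acid at the same place.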